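Removing a Methoxy from Compound 2: Expected Cytotoxicity

A few compounds are considered here, and "the series" means these few. Any claim that something is new, unique, unknown or untested is made for them only; others in the source may bear on it.

Measured compounds:
compound 1 `COc1ccc(-c2cc(/C=C/C(=O)c3ccc(N)cc3)[nH]n2)cc1` -70%
compound 2 `COc1cc(-c2cc(/C=C/C(=O)c3ccc(N)cc3)[nH]n2)cc(OC)c1OC` -51%
compound 3 `COc1ccc(C(=O)/C=C/c2cc(-c3cc(OC)c(OC)c(OC)c3)n[nH]2)cc1` -73%

In a functional assay on NCI-H522 cells (Homo sapiens) for cytotoxicity, read by sulforhodamine B assay, with a stated time of 48 h, tested at 10 uM (on this read-out lower numbers stand for a stronger effect and higher numbers for a weaker effect at the one concentration tested), compound 2 stands highest of the three numbers; compound 1 lies lower and compound 3 lies lowest, both beyond the scatter. Compound 4 `COc1ccc(-c2cc(/C=C/C(=O)c3ccc(N)cc3)[nH]n2)cc1OC` arises from compound 2 by hydrogen in place of methoxy on an aromatic carbon. Going by the values given here, the one measured step, a number 22 percentage points lower from compound 2 to compound 3 (beyond the scatter), concerns a different group and does not bear on this change. Differing from compound 2 at two places, compound 1 gives -70%, so fewer methoxy groups on this ring went with a lower number there. Compound 4 is therefore expected to fall between them, a number 9 percentage points lower from compound 2 to compound 4 (within the scatter), estimated at -60% with a range from -78% to -42%.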

Compound 4, a percentage reported as activity, at one concentration (the size of the read-out at that concentration, not a potency): -84%
The estimate for compound 4 lay 24 percentage points above the measured number; the whole stated range lies above it.
By their numbers in this assay, from the lowest: compound 4; then compounds 3 and 1 (each within the scatter of the next); then compound 2.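

In this assay, hydrogen in place of this methoxy gives a number 33 percentage points lower from compound 2 to compound 4 (beyond the scatter), while methoxy in place of hydrogen gives a number 14 percentage points lower from compound 1 to compound 4 (beyond the scatter). Both steps end at compound 4, so across these three compounds the number does not move in one direction with the count of methoxy groups on this ring. Nothing available here accounts for this reversal. Going by these compounds, whether a hydroxyl or a chlorine on this aromatic carbon would behave like the hydrogen remains open. So does whether the same change would give a similar step in compound 3.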